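The source may hold more compounds than are shown below. What is called first, only, known or untested is meant among the compounds shown, and "the series" means these compounds.

Among the compounds with values here, compound 1 `COc1ccc(Nc2nc(-c3cccc(F)c3)nc3ccc(F)cc23)cc1` is the only member of this small set with a number in a functional assay on HT29-AK cells (Homo sapiens) for cytotoxicity, read by MTT assay, with a stated time of 48 h; on this read-out lower numbers stand for stronger inhibition and higher numbers for weaker inhibition: compound 1 gives 42300 nM. Compound 2 `Fc1cccc(-c2nc(Nc3ccccc3F)c3cc(F)ccc3n2)c1` reaches only the limit of the assay, > 50000 nM. Compound 3 `Fc1cccc(-c2nc(Nc3cccc(Cl)c3)c3cc(F)ccc3n2)c1` likewise stops at the limit, > 50000 nM. Hence the steps of an at least 1.1-fold higher number from compound 1 to compound 2 (0.07 log units; that floor lies within the scatter) and an at least 1.1-fold higher number from compound 1 to compound 3 (0.07 log units; that floor lies within the scatter) are floors rather than sizes, and a step that the two limits leave unreadable from compound 2 to compound 3 cannot be read; both limits sit at the limit of > 50000 nM in this assay, at which 2 of the 3 values shown sit.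

Compound 4 `Cc1ccc(Nc2nc(-c3cccc(F)c3)nc3ccc(F)cc23)cc1` differs from compound 1 by methyl in place of methoxy on an aromatic carbon, a change on an aromatic carbon of a six-membered aromatic ring of carbon only, para to a large group. Within the data shown here, none of the measured steps alters this group alone: each exchanges the whole 4-methoxyphenyl for a different aryl group on the nitrogen and ends at the limit, so they fix no direction for a change confined to the para substituent. A change of this small scope is expected to move the read-out little, so compound 4 is expected to give 48000 nM, between 20000 nM and 120000 nM. The expected step of a 1.1-fold higher number from compound 1 to compound 4 (0.05 log units; within the scatter) is estimated to stay within the scatter, with a real chance that only a limit is returned.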

Compound 4, half-maximal inhibitory concentration: > 50000 nM
Compound 4 gave a limit, no number (the forecaster's own chance of this, stated with the estimate: 50%); middle value at least 1.0-fold (0.01 log units) from the limit.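

Methyl in place of methoxy, para to a large group, is the first change in the series confined to this one substituent, and in this assay compound 4 ends at a limit, > 50000 nM. The step is an at least 1.1-fold higher number from compound 1 to compound 4 (0.07 log units; that floor lies within the scatter); it is a floor and not a size, so the change has no readable direction, yet it shows that a 4-substituted phenyl on the nitrogen does not by itself keep the read-out on scale. The steps from compound 2 and from compound 3 to compound 4 cannot be read, since all three compounds stop at the same limit: the limit of > 50000 nM in this assay, at which 3 of the 4 values shown sit.

Open, on these data alone, is whether any group at this position gives a number clearly stronger than compound 1, for instance an amine, a hydroxyl or a longer ether chain such as ethoxy. Also open, as far as these compounds go, is whether methoxy keeps its on-scale number when the rest of the shared core is changed.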